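Removing a Phenyl from a Ring Nitrogen: Compound 4

The compounds below may be only part of what the source reports. "The series", "measured", "known", "first", "only" and "open" are said of these compounds alone.

Three compounds share a common core and were tested in a functional assay on K562 cells (Homo sapiens) for antiproliferative activity, read by sulforhodamine B assay, with a stated time of 72 h; a higher number here means a weaker inhibitor, a lower number a stronger inhibitor. Compound 1 `O=C1CS/C(=N/Nc2nncc3ccccc23)N1c1ccccc1` gives 57 nM in this assay. Compound 3 `S=C(NNc1nncc2ccccc12)Nc1ccccc1` gives 76 nM, a number so close to that of compound 1 that the two cannot be told apart within the usual scatter. Compound 2 `C(=C/c1ccccc1)\C(=N\Nc1nncc2ccccc12)c1ccccc1` gives 4.4 nM, far lower than the number for compound 1 and well beyond the scatter, so compound 1 sits second highest of the three measured numbers.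

Compound 4 `O=C1CS/C(=N/Nc2nncc3ccccc23)N1` has not yet been measured. It differs from compound 1 in one place: hydrogen in place of phenyl on an amide-type nitrogen in a ring. Among the measured compounds shown here, no pair of measured compounds shows this kind of change, so nothing measured here tells how large its effect will be. My expectation is that losing the phenyl will weaken the inhibitor somewhat, an upward step a 2.6-fold higher number from compound 1 to compound 4 (0.42 log units; beyond the scatter) from compound 1 to compound 4 that lies beyond the scatter. For compound 4 the estimated value in this assay is 150 nM, with a likely range from 50 nM to 500 nM.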

Compound 4, half-maximal inhibitory concentration: 85 nM
Beside the measured number, compound 4's estimate is 1.8-fold (0.25 log units) above it; measured number inside the range.
By their numbers in this assay, from the lowest: compound 2; then compounds 1, 3 and 4 (each within the scatter of the next).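

In this assay, hydrogen in place of phenyl on the amide-type nitrogen in the ring gives a small step (a 1.5-fold higher number from compound 1 to compound 4 (0.17 log units; within the scatter)), so compound 4 cannot be told apart from compound 1. Among the compounds shown here, this pair shows what the earlier compounds could not: at this position, the whole phenyl ring can go without a change that stands out from the usual scatter of repeated measurements. No measurement at hand explains this result.

From the compounds shown here alone, whether a small group such as methyl, a longer chain such as n-butyl, or a benzyl group on this nitrogen would move the number beyond the scatter remains open. Going by these compounds, it is also open whether a chain ending in an amine or a carboxylic acid would be accepted here as readily as hydrogen and phenyl are.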